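The compounds below may be only part of what the source reports. "The series", "measured", "known", "first", "only" and "open" are said of these compounds alone.

Notes on the series. Compound 1 `O=C1NCCc2nc(C#Cc3ccccc3)sc21` carries an unsubstituted ring amide on the shared core. In an assay on HEK293 cells for negative allosteric modulation of metabotropic glutamate receptor 5 (Homo sapiens), read by FLIPR, with a stated time of 1 h (on this read-out lower numbers stand for stronger inhibition and higher numbers for weaker inhibition), compound 1 gives only a limit, > 10000 nM. Compound 2 `CC1CC(C(=O)N2CCc3nc(C#Cc4ccccc4)sc3C2)C1` bears a (3-methylcyclobutyl)carbonyl on the amide-type ring nitrogen of the same core. In this assay compound 2 likewise gives only a limit, > 10000 nM. Within the data shown here, compound 2 thus stands at the limit, and both values shown sit there (the limit of > 10000 nM in this assay, at which 2 of the 2 values shown sit); no step between measured compounds can be read from them. Compound 3 `O=C(N1CCCC1)N1CCc2nc(C#Cc3ccccc3)sc2C1` is not yet measured. It differs from compound 2 as follows: pyrrolidin-1-yl in place of 3-methylcyclobutyl on a carbonyl carbon. With both measured compounds at the limit, the step of a number no higher from compound 2 to compound 3 (the limit leaves the size open) is expected to be none beyond the scatter. Compound 3 is therefore expected to give 10000 nM in this assay, within 3000 nM to 30000 nM, most likely again reported only as a limit.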

Compound 3, half-maximal inhibitory concentration: > 10000 nM
Compound 3 gave a limit, no number; the forecaster's own chance of this, stated with the estimate: 75%; the middle value lies on the limit itself.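

In this assay compound 3 gives only a limit (> 10000 nM). Compound 2 also stands at a limit, so no step from compound 2 to compound 3 can be read: the limit of > 10000 nM in this assay, at which 3 of the 3 values shown sit.

The compounds shown leave open whether any group on this carbonyl carbon of the shared core gives a number in this assay rather than a limit.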